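A Longer Amino Chain at the Same Ring Position

A few compounds are considered here, and "the series" means these few. Any claim that something is new, unique, unknown or untested is made for them only; others in the source may bear on it.

Measured compounds:
compound 1, `CSc1nccc2c1ncn2C1O[C@H](CO)[C@@H](O)[C@H]1O`: < 5%
compound 2, `CN(C)c1nccc2c1ncn2C1O[C@H](CO)[C@@H](O)[C@H]1O`: 10%

In a functional assay on EL4 cells (Mus musculus) for inhibition, tested at 100 uM (on this read-out lower numbers stand for less inhibition and higher numbers for more inhibition at the one concentration tested (going by the name of the read-out)), compound 1 shows < 5%, which is a limit of the assay rather than a number. Going by the values given here, compound 2 gives 10% in this assay, the only actual number among the two values shown. For compound 1 the value is a limit, as the limit of < 5% in this assay, at which 1 of the 2 values shown sits, records. Among the compounds with values here, the one measured step, a number at least 5 percentage points higher from compound 1 to compound 2 (that floor lies within the scatter), has a floor that lies within the scatter, so it does not show a clear effect of exchanging the group at this position.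

Compound 3, `CCCCCCNc1nccc2c1ncn2C1O[C@H](CO)[C@@H](O)[C@H]1O`, is not yet measured. Its difference from compound 2 is hexylamino in place of dimethylamino on an aromatic carbon. Within the data shown here, the only step that touches this position is the one from compound 1 to compound 2, and it was small. Among the measured compounds shown here, with no measured step pointing in either direction, compound 3 is expected to show no change beyond the scatter, a step of no change at the digits printed from compound 2 to compound 3 (within the scatter). Compound 3 is therefore estimated at 10%, within a range from 0% to 25%.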

Compound 3, a percentage reported as inhibition, at one concentration (the size of the read-out at that concentration, not a potency): 14%
The estimate for compound 3 lay 4 percentage points below the measured number; the range from low to high includes it.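

On this aromatic carbon, hexylamino in place of dimethylamino gives a number 4 percentage points higher from compound 2 to compound 3 (within the scatter), so the longer chain, with a hydrogen-bond donor that dimethylamino does not have, brings no clear change in this assay. Set against methylsulfanyl, hexylamino gives a number at least 9 percentage points higher from compound 1 to compound 3 (that floor lies within the scatter), and this step likewise does not establish an effect of the exchange. The value of compound 1 is a limit rather than a number, which leaves that step with only a floor: the limit of < 5% in this assay, at which 1 of the 3 values shown sits.

The compounds shown leave open whether a primary amine, a cyclic amine such as morpholine, a carboxylic acid or a chain longer than hexylamino on this aromatic carbon would move the read-out in this assay beyond the scatter. They also leave open whether a change elsewhere on the shared core would do so, and how any of these compounds would read at a concentration other than the one tested.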